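Trimming the butyl group of compound 3

The source may report more compounds than this note shows. Statements on the series, on what has been measured and on what is new or still open speak of the compounds shown alone.

In a functional assay on A-375 cells (Homo sapiens) for cytotoxicity, read by MTT assay, with a stated time of 72 h (on this read-out higher numbers stand for weaker inhibition and lower numbers for stronger inhibition), three compounds sharing one core have been measured. Compound 1 `O=C1c2c[n+]([O-])c3ccccc3c2C(=O)c2c1c1ccccc1n2CCCCn1ccnc1`, carrying 1H-imidazol-1-yl, gives 350 nM. Compound 2 `CN1CCN(CCCCn2c3c(c4ccccc42)C(=O)c2c[n+]([O-])c4ccccc4c2C3=O)CC1`, carrying 4-methylpiperazin-1-yl, gives 30 nM. Compound 3 `CCCCN1CCN(CCCCn2c3c(c4ccccc42)C(=O)c2c[n+]([O-])c4ccccc4c2C3=O)CC1`, carrying 4-butylpiperazin-1-yl, gives 2150 nM, the highest number of the three and so the weakest inhibition. Its distance from the other two is shown by a 6.1-fold higher number from compound 1 to compound 3 (0.79 log units; beyond the scatter) and a 72-fold higher number from compound 2 to compound 3 (1.86 log units; beyond the scatter).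

Compound 4 `CCCN1CCN(CCCCn2c3c(c4ccccc42)C(=O)c2c[n+]([O-])c4ccccc4c2C3=O)CC1` departs from compound 3 by a single change, hydrogen in place of methyl on a saturated chain carbon, three bonds along the chain from an amine nitrogen in a ring, which turns butyl to propyl. Among the measured compounds shown here, the most relevant measured change is a 72-fold higher number from compound 2 to compound 3 (1.86 log units; beyond the scatter), the only one confined to the group on the piperazine. The change a 12-fold lower number from compound 1 to compound 2 (1.07 log units; beyond the scatter) swaps the whole imidazole group and bears on this question less directly. For the measured compounds named here, no measured compound lies between methyl and butyl, so the shape of that large climb is unknown. Compound 4 is expected to recover part of it, and a moderate move toward stronger inhibition is expected, a 3.6-fold lower number from compound 3 to compound 4 (0.55 log units; beyond the scatter). For compound 4 the estimate is 600 nM, with an expected range from 150 nM to 2000 nM.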

Compound 4, half-maximal inhibitory concentration: 870 nM
The estimate for compound 4 lay 1.5-fold (0.16 log units) below the measured number; low and high end bracket the measured number.
By their numbers in this assay, from the lowest: compound 2; then compound 1; then compound 4; then compound 3.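

In this assay the step from butyl to propyl gives a 2.5-fold lower number from compound 3 to compound 4 (0.39 log units; beyond the scatter) and shows that the outermost carbon of the chain on the piperazine still counts, though only modestly. Set against a 72-fold higher number from compound 2 to compound 3 (1.86 log units; beyond the scatter) for the whole change from methyl to butyl, the step of a 29-fold higher number from compound 2 to compound 4 (1.46 log units; beyond the scatter) shows that most of the climb is already present at propyl, so the loss is not spread evenly along the chain but falls largely before the last carbon is added. The step of a 2.5-fold higher number from compound 1 to compound 4 (0.40 log units; beyond the scatter) also leaves propyl on the weaker side of the imidazole, so among the three piperazines shown, only the 4-methylpiperazin-1-yl group gives a lower number than 1H-imidazol-1-yl.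

Whether the large rise between methyl and propyl comes gradually or at once stays open, since an ethyl group on the piperazine is not among these compounds, and neither a piperazine carrying hydrogen nor a pentyl chain shows how the series behaves at either end. Nothing given here accounts for why these steps take the size they do.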